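Removing the Fluoro Group from Compound 2

This account rests on a few compounds, and the source may have more. Where it says the series, first, only, none or still open, it means among the compounds named here.

For the measured compounds named here, compound 2, with the structure `Nc1nc(=O)n(C2OC(CO)C(Cl)C2O)cc1F`, is one of two compounds measured in a functional assay on L5178Y cells (Mus musculus) for antiproliferative activity; a lower number here means a stronger inhibitor, a higher number a weaker inhibitor. In this assay compound 2 gives 1 ug/mL, the highest of the two numbers. Going by the values given here, the only neighbour is compound 1, with the structure `Cc1ccc(S(=O)(=O)O[C@@H]2[C@@H](O)[C@H](n3ccc(N)nc3=O)O[C@@H]2CO)cc1`, which in this assay gives 0.08 ug/mL, a value that lies well beyond the scatter of the method compared with compound 2; no single-point comparison connects these two structures, so their two values alone tell the story.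

Compound 3, with the structure `Nc1ccn(C2OC(CO)C(Cl)C2O)c(=O)n1`, is not yet measured. It differs from compound 2 in one place: hydrogen in place of fluoro on an aromatic carbon. The change sits on an aromatic carbon of a six-membered aromatic ring with two nitrogens, ortho to an amino group, so the rest of the molecule stays as in compound 2.

Among the compounds with values here, no measured pair shows what this change does here. The step from a 2.0-fold higher number from compound 2 to compound 3 (0.30 log units; within the scatter) is expected to be small, most likely a modest weakening, possibly none beyond the scatter. Compound 3 is therefore estimated at 2 ug/mL, within a range of 0.5 ug/mL to 8 ug/mL.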

Compound 3, concentration for 50% inhibition: 2 ug/mL
The estimate for compound 3 equals the measured number at the digits printed, within the range that was stated.
By their numbers in this assay, from the lowest: compound 1; then compounds 2 and 3 (each within the scatter of the next).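

In this assay, hydrogen in place of fluoro on this aromatic carbon, ortho to an amino group, gives a 2.0-fold higher number from compound 2 to compound 3 (0.30 log units; within the scatter) and so leaves the two compounds indistinguishable. For the compounds shown here, this is the first comparison in the set in which only one place differs, and it shows that, in this pair, the fluoro group at this position is not needed to keep the number at this level. No data shown here explain why this exchange leaves the two numbers within the scatter.

The compounds shown leave open whether another group on this aromatic carbon, such as bromo, methyl, methoxy or trifluoromethyl, would shift the number beyond the scatter, since fluoro and hydrogen are the only two compared here. They also leave open what replacing the chloro group shared by compound 2 and compound 3 with a hydroxyl or an amine would do, and compound 1 differs from both in more than one place, so its lower number cannot be assigned to any single change.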